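The compounds below may be only part of what the source reports. "The series", "measured", "known", "first", "only" and "open" are said of these compounds alone.

The series shares one core. For the measured compounds named here, compound 1 `CCCCSc1sc2nc(-c3cccs3)cc(-c3ccccc3)c2c1N` is the first member; in an assay for inhibition of 15-hydroxyprostaglandin dehydrogenase [NAD(+)] (Homo sapiens), read by fluorescence, with a stated time of 15 min, in the presence of a further agent that is not named here (a lower number here means a stronger inhibitor, a higher number a weaker inhibitor), compound 1 gives only a limit, > 80 nM. Going by the values given here, compound 2 `Nc1c([S+]([O-])CCCCl)sc2nc(-c3cccs3)cc(-c3ccccc3)c12` differs from it at one place on an aromatic carbon, and in this assay compound 2 gives 4 nM, the single number measured so far. Among the compounds with values here, the only measured step is an at least 20-fold lower number from compound 1 to compound 2 (1.30 log units; beyond the scatter), and it rests on (the limit of > 80 nM in this assay, at which 1 of the 2 values shown sits). Compound 2 therefore stands as the sole numbered point, with compound 1 known as a limit alone.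

Compound 3 `CCCCCC[S+]([O-])c1sc2nc(-c3cccs3)cc(-c3ccccc3)c2c1N` differs from compound 2 by propyl in place of chloro on a saturated chain carbon, three bonds along the chain from a sulfur. Within the data shown here, no measured step alters the chain end on its own: the step from compound 1 to compound 2 changed the whole group at the aromatic carbon at once, so it bears on the present change only loosely and gives no direction for it. A step of a 1.5-fold higher number from compound 2 to compound 3 (0.18 log units; within the scatter) is expected, within the scatter. Compound 3 is accordingly estimated at 6 nM in this assay, with a range from 2 nM to 20 nM.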

Compound 3, half-maximal inhibitory concentration: 18 nM
Estimate against measurement, compound 3: 3.0-fold (0.48 log units) below; measured number inside the range.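

In this assay, for the compounds shown here, the chain end counts on its own: propyl in place of chloro, on a saturated chain carbon, three bonds along the chain from a sulfur, gives a 4.5-fold higher number from compound 2 to compound 3 (0.65 log units; beyond the scatter) and is the first change confined to this position. Between these two compounds, 3-chloropropyl is therefore preferred to hexyl, which the earlier step could not show, since it changed the whole group on the aromatic carbon at once. From the compounds shown here alone, the chlorine is still not required for a measurable gain over compound 1, as the group in compound 3 gives an at least 4.4-fold lower number from compound 1 to compound 3 (0.64 log units; beyond the scatter) and the true size of this step stays unknown, with only a limit on one side: the limit of > 80 nM in this assay, at which 1 of the 3 values shown sits.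

The compounds shown do not separate the part played by the oxygen on the sulfur from that of the chain, so a pair differing only in that oxygen would be needed to assign the gain over compound 1. Going by these compounds, it also remains open how a plain propyl chain, or a chain ending in fluorine, a hydroxyl group or an amine, would compare with the 3-chloropropyl group.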